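The source may report more compounds than this note shows. Statements on the series, on what has been measured and on what is new or still open speak of the compounds shown alone.

Of the compounds shown here, two built on a shared core have been tested in a functional assay on HepG2 cells (Homo sapiens) for antiproliferative activity, read by MTT assay, with a stated time of 48 h; a lower number here means a stronger inhibitor, a higher number a weaker inhibitor. Compound 1 `N#CC1=C(N)Oc2c(N)cc3nc4ccccc4nc3c2C12C(=O)N(Cc1cnnn1-c1ccccc1Br)c1ccccc12` gives 38000 nM. Compound 2 `Cc1cc(C)c(-n2nncc2CN2C(=O)C3(C(C#N)=C(N)Oc4c(N)cc5nc6ccccc6nc5c43)c3ccccc32)c(C)c1` gives 48100 nM, and these two numbers lie within the usual scatter of each other, so neither compound can be set apart from the other on this evidence. Among the compounds with values here, the only measured step, a 1.3-fold higher number from compound 1 to compound 2 (0.10 log units; within the scatter), exchanged a 2-bromophenyl for a 2,4,6-trimethylphenyl on an aromatic nitrogen. Compound 3 `N#CC1=C(N)Oc2c(N)cc3nc4ccccc4nc3c2C12C(=O)N(Cc1cnnn1-c1c(Cl)cc(Cl)cc1Cl)c1ccccc12` alters that same position once more: 2,4,6-trichlorophenyl in place of 2,4,6-trimethylphenyl on an aromatic nitrogen. Within the data shown here, the earlier step touched the same group at the same place and moved the number only within the scatter, which makes it the one piece of evidence bearing on the present change. The expectation for compound 3 in this assay is accordingly a step of a 1.1-fold lower number from compound 2 to compound 3 (0.03 log units; within the scatter), not beyond the scatter. Compound 3 is estimated at 45000 nM, with a likely range from 20000 nM to 100000 nM.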

Compound 3, half-maximal inhibitory concentration: 37800 nM
Estimate against measurement, compound 3: 1.2-fold (0.08 log units) above; the range from low to high includes it.
By their numbers in this assay, from the lowest: compounds 3, 1 and 2 (each within the scatter of the next).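

Swapping the 2,4,6-trimethylphenyl for the 2,4,6-trichlorophenyl in this assay gives a 1.3-fold lower number from compound 2 to compound 3 (0.10 log units; within the scatter) and so does not separate these two groups, even though all three methyl groups give way to chlorine. Setting the 2,4,6-trichlorophenyl against the 2-bromophenyl gives a 1.0-fold lower number from compound 1 to compound 3 (0.00 log units; within the scatter) and leaves those two equally inseparable, so all three compounds now read alike in this assay whether this aromatic nitrogen carries one ring substituent or three, and whether those are bromine, chlorine or methyl. No measurement shown here explains this likeness.

On these data alone, all three groups are substituted phenyl rings, so the effect of a plain phenyl, a benzyl or a pyridine ring at this position remains open. So does that of a phenyl ring bearing an amine or a carboxylic acid.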